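This account rests on a few compounds, and the source may have more. Where it says the series, first, only, none or still open, it means among the compounds named here.

Measured in a functional assay on HCT-116 cells (Homo sapiens) for antiproliferative activity, read by MTT assay, with a stated time of 48 h; a higher number here means a weaker inhibitor, a lower number a stronger inhibitor:
Compound 1 `CCCCCCCC(CCO)n1cnc2c(OC)ncnc21`: 15300 nM
Compound 2 `CCCCCCCC(CCO)n1cnc2c(N)ncnc21`: > 50000 nM, a limit and not a number

Compound 2 has no exact position on the scale. It is known only through (the limit of > 50000 nM in this assay, at which 1 of the 2 values shown sits).

Compound 3 `CCCCCCCCC(CCO)n1cnc2c(N)ncnc21` keeps the amino group of compound 2 and changes only the chain: methyl in place of hydrogen on a saturated chain carbon, eight bonds along the chain from an aromatic nitrogen. This places methyl in place of hydrogen on a saturated chain carbon, eight bonds along the chain from an aromatic nitrogen.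

For the measured compounds named here, the only measured step is an at least 3.2-fold higher number from compound 1 to compound 2 (0.51 log units; beyond the scatter). Going by the values given here, that step is amino in place of methoxy on an aromatic carbon, so it is a different change from the one in compound 3. Among the compounds with values here, it shows only that the amino member of the pair gave the higher number. Within the data shown here, no measured step tests a change to the chain, so the expectation in this assay is for no step beyond the scatter, in either direction, and compound 3 may well also reach the limit.

The expected step is a number no higher from compound 2 to compound 3 (the limit leaves the size open).

For compound 3, the estimated value is 50000 nM, with an expected range of 25000 nM to 100000 nM.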

Compound 3, half-maximal inhibitory concentration: 11600 nM
Compound 3: middle estimate off by 4.3-fold (0.63 log units), on the high side; measured number outside the range, below it.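

In this assay, methyl in place of hydrogen on a saturated chain carbon, eight bonds along the chain from an aromatic nitrogen, gives an at least 4.3-fold lower number from compound 2 to compound 3 (0.63 log units; beyond the scatter). For the compounds shown here, the only earlier step was a change on an aromatic carbon, so this is the first sign that the chain, and not only the group on the core, can move the number, and that an amino compound can give a measured value in this assay rather than a limit. The step has a lower bound only, and its true size stays unknown because compound 2 is known solely through a limit: the limit of > 50000 nM in this assay, at which 1 of the 3 values shown sits.

Going by these compounds, whether the same added methyl would also lower the number with methoxy in place of amino on the core stays open. On these data alone, it is equally open whether a still longer chain, or a carboxylic acid in place of the hydroxyl at the other chain end, would lower the number further or raise it again.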